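Side chain at the aromatic oxygen, compound 2 to compound 4

The compounds below may be only part of what the source reports. "The series", "measured", "known", "first", "only" and "open" are said of these compounds alone.

Measured so far in an assay on cells with melanin-concentrating hormone receptor 1 (Homo sapiens) as the target, read by radioligand binding; on this read-out higher numbers stand for weaker inhibition and lower numbers for stronger inhibition:
- compound 1, `CC(CC(C)(C)C)Oc1cccc2cccnc12`: compound 1 gives > 2000 nM, which is a limit of the assay and not a number.
- compound 2, `CCOCC(C)Oc1cccc2ccc(N)nc12`: compound 2 gives 1070 nM.
- compound 3, `Nc1ccc2cccc(OCC3CC4CCC3C4)c2n1`: compound 3 gives 137 nM.

Compound 2 stands at the highest of the two numbers shown. The nearest is compound 3, which sits at a clearly lower number, a gap beyond the scatter. Compound 1 sits at the limit of > 2000 nM in this assay, at which 1 of the 3 values shown sits. For the measured compounds named here, compound 1 and compound 2 differ in more than one place, so their two values are read side by side and no step is drawn between them.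

Compound 4, `CCCOc1cccc2ccc(N)nc12`, has not been measured. It differs from compound 2 as follows: a group of 3 heavy atoms (3 carbon; no ring) in place of a group of 6 heavy atoms (5 carbon, 1 oxygen; no ring), on an oxygen on an aromatic ring. The group that leaves carries one hydrogen-bond acceptor; propyl carries none.

Going by the values given here, no measured step touches this change. The expected step in this assay from compound 2 to compound 4 is a 1.4-fold higher number from compound 2 to compound 4 (0.15 log units; within the scatter), judged small and toward a weaker number, not clearly beyond the scatter. On that basis compound 4 is estimated at 1500 nM, with a range from 500 nM to 4500 nM, and some chance that only a limit is returned.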

Compound 4, half-maximal inhibitory concentration: 1100 nM
Beside the measured number, compound 4's estimate is 1.4-fold (0.13 log units) above it, within the range that was stated.
By their numbers in this assay, from the lowest: compound 3; then compounds 2 and 4 (each within the scatter of the next). At a limit, above all of these: compound 1.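

The step in this assay is a 1.0-fold higher number from compound 2 to compound 4 (0.01 log units; within the scatter), the first direct read on this side chain. On an oxygen on an aromatic ring, propyl and the group of 6 heavy atoms with its one hydrogen-bond acceptor cannot be told apart here, so neither the acceptor nor the difference in heavy atoms of these open chains registers in the reading for this pair. Against that flat pair, compound 3, whose group on the same oxygen carries a ring, gives 137 nM and stands clearly apart from the open chains at this position.

Nothing measured here bears on why compound 2 and compound 4 read alike. Still open, going by these compounds, is whether a longer chain, an amine or a carboxylic acid on this oxygen would depart from the propyl reading, and whether the ring in compound 3 or simply the size of its group goes with its lower number.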